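Cyclohexyl in place of cyclopropyl on the ring nitrogen

The source may hold more compounds than are shown below. What is called first, only, known or untested is meant among the compounds shown, and "the series" means these compounds.

Compound 1 `O=c1cc(NC2CC2)cc(-c2ccccc2)o1` carries a cyclopropyl group on the nitrogen of its shared core. In a functional assay on KB cells (Homo sapiens) for cytotoxicity, read by MTT assay, with a stated time of 72 h (a higher number here means that more compound is needed for the effect, a lower number that less compound is needed), compound 1 gives > 30 uM, which is a limit of the assay and not a number (the limit of > 30 uM in this assay, at which 1 of the 3 values shown sits). Compound 2 `CCCCCc1cc(Nc2ccc(OC)cc2)cc(=O)o1` gives 10.1 uM in this assay. Compound 3 `COc1ccc(Nc2cc(-c3ccco3)oc(=O)c2)cc1` gives 2.66 uM in this assay. Going by the values given here, the one measured step, a 3.8-fold lower number from compound 2 to compound 3 (0.58 log units; beyond the scatter), concerns the group on an aromatic carbon of the core and leaves the nitrogen untouched, so it does not bear on the change at hand. Compound 4 `O=c1cc(NC2CCCCC2)cc(-c2ccccc2)o1` differs from compound 1 by cyclohexyl in place of cyclopropyl on a nitrogen on an aromatic ring. Among the compounds with values here, no measured step follows this change, and compound 1 itself stands only at a limit, so compound 4 is expected to remain in the weak range, with no step beyond the scatter foreseen. Compound 4 is estimated at 25 uM in this assay, between 8 uM and 60 uM. The step so estimated is an at least 1.2-fold lower number from compound 1 to compound 4 (0.07 log units; that floor lies within the scatter) in this assay.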

Compound 4, concentration for half-maximal effect: 16 uM
Beside the measured number, compound 4's estimate is 1.6-fold (0.19 log units) above it; the range from low to high includes it.
By their numbers in this assay, from the lowest: compound 3; then compounds 2 and 4 (each within the scatter of the next). At a limit, above all of these: compound 1.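

In this assay, cyclohexyl in place of cyclopropyl on a nitrogen on an aromatic ring gives an at least 1.8-fold lower number from compound 1 to compound 4 (0.27 log units; that floor lies within the scatter), the only step shown at this position. Going by these compounds alone, it shows that, with this larger carbon ring on the nitrogen, the core of compound 1 gives a measurable number in this assay, which the earlier compounds could not show. The true size of the step cannot be read, because compound 1 stands at a limit of the assay: the limit of > 30 uM in this assay, at which 1 of the 4 values shown sits.

The compounds shown leave open whether a cyclopentyl group, of intermediate ring size, would fall in line with compound 4 on this nitrogen. They also leave open what an open chain such as pentyl, or a ring bearing an amine or a hydroxyl group, would do there.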